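Aryl ether variation on the shared core

A few compounds are considered here, and "the series" means these few. Any claim that something is new, unique, unknown or untested is made for them only; others in the source may bear on it.

Three compounds share one core and differ in the ring-held heteroatom and in the substitution of the aryl ether. Compound 1 `NC1=NC2(CCSCC2)N(OCCCOc2ccc(Cl)c(Cl)c2)C(N)=N1` gives 88.4% in an assay on isolated protein for inhibition of Dihydrofolate reductase (Homo sapiens), read by spectrophotometry, using NADPH, with stated times of 5 s and 6 min, tested at 5 uM; a lower number here means a weaker effect, a higher number a stronger effect of the compound at the concentration tested; compound 3 `NC1=NC2(CCSCC2)N(OCCCOc2cc(Cl)c(Cl)cc2Cl)C(N)=N1` gives 84.4%; compound 2 `NC1=NC2(CCOCC2)N(OCCCOc2ccccc2Cl)C(N)=N1` gives 83.3%. All three numbers sit within the usual scatter of one another, so compound 2 cannot be placed above or below its neighbours on this evidence.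

Compound 4 `Cc1ccc(OCCCON2C(N)=NC(N)=NC23CCOCC3)cc1` is not yet measured. Relative to compound 2 the change is 4-methylphenyl in place of 2-chlorophenyl on an oxygen on a saturated carbon.

Going by the values given here, the only measured step on the aryl ether, chloro entering on an aromatic carbon, is a number 4 percentage points lower from compound 1 to compound 3 (within the scatter). Among the compounds with values here, no measured step exchanges chloro for methyl or moves a substituent around the ring, so the expectation rests on that single step and on the closeness of all three values. The step from compound 2 to compound 4 is therefore expected to stay within the scatter, with no direction claimed: a number 3.3 percentage points lower from compound 2 to compound 4 (within the scatter). Compound 4 is estimated at 80%, from 62% to 92%.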

Compound 4, a percentage reported as inhibition, at one concentration (the size of the read-out at that concentration, not a potency): > 90%
Compound 4: only a limit was reported; the forecaster's own chance of this, stated with the estimate: 0%; at least 10 percentage points between middle value and limit.
By their numbers in this assay, from the lowest: compounds 2, 3 and 1 (each within the scatter of the next). At a limit, above all of these: compound 4.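

In this assay compound 4 stands at a limit of the assay, > 90%, not at a number. It is the first compound shown with no chloro on the aryl ring, so on an oxygen on a saturated carbon a high reading does not depend on chloro: 4-methylphenyl is tolerated in place of 2-chlorophenyl. The change reads as a number at least 6.7 percentage points higher from compound 2 to compound 4 (that floor lies within the scatter), and its true size stays unfixed because the reading sits at a limit: the limit of > 90% in this assay, at which 1 of the 4 values shown sits.

Going by these compounds, whether 4-methylphenyl truly differs from 2-chlorophenyl beyond the scatter remains open, and a measurement able to resolve readings this high would be needed to settle it. Also open, on these data alone, is how far this position tolerates change, for instance an amine or a carboxylic acid on the aryl ring, or a longer chain carrying the aryl ether.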